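Amino for chloro on the purine-type core: expectation for compound 4

The compounds below may be only part of what the source reports. "The series", "measured", "known", "first", "only" and "open" are said of these compounds alone.

Compound 1 `ClCc1ccccc1Cn1cnc2c(Cl)nc(Cl)nc21` gives 190 nM in a functional assay on HCT-116 cells (Homo sapiens) for cytotoxicity, read by sulforhodamine B assay, with a stated time of 48 h; on this read-out lower numbers stand for stronger inhibition of growth and higher numbers for weaker inhibition of growth. Compound 2 `ClCc1cccc(Cn2cnc3c(Cl)nc(Cl)nc32)c1` has the same atoms joined differently; how the two cores differ is not broken down here, and in this assay compound 2 gives 1620 nM. Compound 3 `Nc1nc(Cl)c2ncn(Cc3ccccc3CCl)c2n1` is compound 1 with amino in place of chloro on an aromatic carbon; in this assay compound 3 gives 3980 nM. The step of a 21-fold higher number from compound 1 to compound 3 (1.32 log units; beyond the scatter) is the only measured instance of this change among the compounds shown. Compound 2 stands second highest of the three numbers, with compound 3 nearest and compound 1 furthest.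

Compound 4 `Nc1nc(Cl)c2ncn(Cc3cccc(CCl)c3)c2n1` has not yet been measured. It differs from compound 2 by amino in place of chloro on an aromatic carbon. This is the same change as that from compound 1 to compound 3: the leaving group, the entering group and the place are the same word for word, so it is the same change and not merely the same kind.

Among the measured compounds shown here, for compound 4 in this assay a step of a 15-fold higher number from compound 2 to compound 4 (1.19 log units; beyond the scatter) is expected, set beside the measured step of a 21-fold higher number from compound 1 to compound 3 (1.32 log units; beyond the scatter) and resting on that single precedent; with only one example of the change the size may not carry over exactly, so a somewhat smaller step is assumed. The estimate for compound 4 is 25000 nM, with a range from 8000 nM to 80000 nM. Whether the change acts alike on the two cores cannot be checked from the data at hand.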

Compound 4, concentration for 50% growth inhibition: 1990 nM
The estimate for compound 4 lay 13-fold (1.10 log units) above the measured number, and the stated range ends above it.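

In this assay, amino in place of chloro on an aromatic carbon gives a 1.2-fold higher number from compound 2 to compound 4 (0.09 log units; within the scatter), so on this core the change leaves the number within the scatter. The same change therefore cannot be carried from one core to another in this series at a fixed size, and the two measured steps differ clearly: the same change on two cores in this assay, a 21-fold higher number (1.32 log units; beyond the scatter) from compound 1 to compound 3 and a 1.2-fold higher number (0.09 log units; within the scatter) from compound 2 to compound 4, 17-fold (1.23 log units) apart, beyond the scatter of two such steps This shows that the result on one core was a poor guide to the result on the other, but with a single pair per core it does not show which feature of the cores sets the size of the step, nor which of the two steps would be the more typical on a further core.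

Open, on these data alone, is whether another group in place of the same chloro, such as methoxy, methylamino or dimethylamino, would follow the large step on the core of compound 1 or the flat one on the core of compound 2. Also open, as far as these compounds go, is whether the gap between the two steps would survive with hydroxymethyl or methyl in place of chloromethyl on the benzyl ring, or in a cell line other than this one.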